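Hydroxy to Nitro: Expected Shift in Rat Brain Binding

A few compounds are considered here, and "the series" means these few. Any claim that something is new, unique, unknown or untested is made for them only; others in the source may bear on it.

Compound 2 `CC[C@]1(c2cccc(O)c2)OC[C@H]([C@@H]2CCCCN2)O1` gives 489 nM in a functional assay (brain) for displacement of a labelled ligand, with Rattus norvegicus as the target (on this read-out lower numbers stand for stronger inhibition and higher numbers for weaker inhibition), the higher of the two numbers recorded so far. Its nearest neighbour, compound 1 `CC[C@]1(c2cccc(Cl)c2)OC[C@H]([C@@H]2CCCCN2)O1`, gives 59 nM, and the step of an 8.3-fold higher number from compound 1 to compound 2 (0.92 log units; beyond the scatter) arose from hydroxy in place of chloro on an aromatic carbon. Compound 3 `CC[C@]1(c2cccc([N+](=O)[O-])c2)OC[C@H]([C@@H]2CCCCN2)O1` carries nitro in place of hydroxy on an aromatic carbon. Among the compounds with values here, no measured step involves nitro, so the single step between compound 1 and compound 2 is the only guide, showing that a change at this aromatic carbon can move the number well beyond the scatter. A lower number than compound 2 is expected for compound 3, a step of a 3.3-fold lower number from compound 2 to compound 3 (0.51 log units; beyond the scatter), with the estimate 150 nM spanning 40 nM to 600 nM.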

Compound 3, inhibition constant: 1320 nM
The estimate for compound 3 lay 8.8-fold (0.94 log units) below the measured number; the whole stated range lies below it.
By their numbers in this assay, from the lowest: compound 1; then compound 2; then compound 3.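

Nitro in place of hydroxy gives a 2.7-fold higher number from compound 2 to compound 3 (0.43 log units; beyond the scatter) in this assay, so a second change at this aromatic carbon also moves the number beyond the scatter. Nitro in place of chloro gives a 22-fold higher number from compound 1 to compound 3 (1.35 log units; beyond the scatter), the largest step among these three compounds. Replacing hydroxy, which has a hydrogen-bond donor, with nitro, which has none, did not bring the number closer to that of compound 1. Nothing measured here explains the order of the three groups. Going by these compounds, whether an amine, a methyl group or a fluorine atom at this carbon would give a number nearer that of chloro or nitro remains open.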